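Cytotoxicity notes on the amide-nitrogen variations of a sulfonylindole series

The source may report more compounds than this note shows. Statements on the series, on what has been measured and on what is new or still open speak of the compounds shown alone.

Measured so far:
compound 1 `Cc1cc(C)cc(S(=O)(=O)c2c(C(=O)NCc3cccc(F)c3F)[nH]c3ccc(Cl)cc23)c1` — > 51100 nM
compound 2 `Cc1cc(C)cc(S(=O)(=O)c2c(C(=O)Nc3ccnc(C#N)c3)[nH]c3ccc(Cl)cc23)c1` — 6840 nM
compound 3 `Cc1cc(C)cc(S(=O)(=O)c2c(C(=O)NCc3n[nH]c4ccccc34)[nH]c3ccc(Cl)cc23)c1` — > 50700 nM

In an ADME assay on MT4 cells (Homo sapiens) for cytotoxicity, read by MTT assay (on this read-out lower numbers stand for higher toxicity in this test and higher numbers for lower toxicity in this test), compound 3 gives only a limit, > 50700 nM, and not a number. Compound 1 likewise sits at a limit in this assay, > 51100 nM (the limit of > 51100 nM in this assay, at which 1 of the 3 values shown sits). Compound 2 is the only one of the three with a read number, 6840 nM. The step from compound 2 to compound 3 is an at least 7.4-fold higher number from compound 2 to compound 3 (0.86 log units; beyond the scatter), while a step that the two limits leave unreadable from compound 1 to compound 3 and cannot be sized because both ends are limits (the limit of > 50700 nM in this assay, at which 1 of the 3 values shown sits).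

Compound 4 `Cc1cc(C)cc(S(=O)(=O)c2c(C(=O)NC(C)C(=O)NCc3ccncc3)[nH]c3ccc(Cl)cc23)c1` is not yet measured in this assay. It differs from compound 3 as follows: a group of 12 heavy atoms (9 carbon, 2 nitrogen, 1 oxygen; one six-membered aromatic ring with 1 hetero atom) in place of a group of 10 heavy atoms (8 carbon, 2 nitrogen; one five-membered aromatic ring with 2 hetero atoms, one six-membered aromatic ring of carbon only), on an amide-type nitrogen.

Going by the values given here, the only readable step onto an amide-nitrogen substituent here, an at least 7.4-fold higher number from compound 2 to compound 3 (0.86 log units; beyond the scatter), shows that exchanging the group on that nitrogen can move this read-out well beyond the scatter, and the two limit values show that compounds 1 and 3 both sit at the upper edge of what the assay reports. The change to compound 4 is of the same kind, on the same nitrogen. Compound 4 is therefore expected to stay near the limit, with an at least 1.2-fold lower number from compound 3 to compound 4 (0.10 log units; that floor lies within the scatter) as the estimated step. The estimate for compound 4 in this assay is 40000 nM, expected between 10000 nM and 70000 nM.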

Compound 4, half-maximal cytotoxic concentration: 19500 nM
For compound 4 the middle estimate is 2.1-fold (0.31 log units) above the measured one; low and high end bracket the measured number.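

In this assay, going by these compounds alone, the amide-type nitrogen with a group of 12 heavy atoms, including one six-membered aromatic ring with 1 hetero atom, gives an intermediate level that the earlier compounds did not show, with an at least 2.6-fold lower number from compound 3 to compound 4 (0.41 log units; beyond the scatter) and an at least 2.6-fold lower number from compound 1 to compound 4 (0.41 log units; beyond the scatter) on one side and a 2.9-fold higher number from compound 2 to compound 4 (0.45 log units; beyond the scatter) on the other, all three beyond the scatter. The step from compound 3 is a floor, because compound 3 gives a limit and not a number: the limit of > 50700 nM in this assay, at which 1 of the 4 values shown sits. The step from compound 1 is likewise a floor, because compound 1 also gives a limit: the limit of > 51100 nM in this assay, at which 1 of the 4 values shown sits.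

Which part of the entering group sets this level remains open, as the group differs from each of the others in several features at once, including its double bond outside aromatic rings and its ring. A longer chain on the same nitrogen, or an amine or a carboxylic acid in place of the six-membered aromatic ring, would show whether the chain or the ring carries the change in this read-out in this assay.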